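Series notes: ester in place of ketone at compound 3

A few compounds are considered here, and "the series" means these few. Any claim that something is new, unique, unknown or untested is made for them only; others in the source may bear on it.

Compound 3 `CC(=O)/C(=C/c1c(-c2ccccc2)[nH]c2ccccc12)C(=O)c1ccccc1` stands only as a limit in a functional assay on SK-MEL-28 cells (Homo sapiens) for cytotoxicity, read by MTT assay, with a stated time of 96 h; on this read-out lower numbers stand for an effect already at smaller amounts and higher numbers for an effect only at larger amounts of compound. In this assay compound 3 gives > 100000 nM, which is a limit of the assay and not a number. The two companions sit the same way. Compound 1 `COc1ccc(-c2[nH]c3ccccc3c2/C=C(\C#N)S(=O)(=O)c2ccccc2)cc1` gives > 100000 nM in this assay, again a limit. Compound 2 `COc1ccc(-c2[nH]c3ccc(OC)cc3c2/C=C(\C#N)S(=O)(=O)c2ccccc2)cc1` gives > 100000 nM, also a limit. Going by the values given here, the one step between measured compounds, a step that the two limits leave unreadable from compound 1 to compound 2, methoxy in place of hydrogen on an aromatic carbon, is therefore unreadable in size. Among the compounds with values here, what the three share is the limit of > 100000 nM in this assay, at which 3 of the 3 values shown sit; no measured step in the set yields a readable size or direction.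

The step to compound 4 `CCOC(=O)/C(=C/c1c(-c2ccccc2)[nH]c2ccccc12)C(=O)c1ccccc1` is ethoxy in place of methyl on a carbonyl carbon; cut one bond further out it reads acetyl to ethoxycarbonyl. Within the data shown here, no measured step bears on this change, and compound 3 itself offers only a limit, so nothing in the numbers points in either direction. The expectation is that the assay will again report a limit for compound 4, the step being estimated as a step that the limit leaves unreadable from compound 3 to compound 4, none beyond the scatter. Should a number be returned, compound 4 is estimated at 200000 nM, with a range from 60000 nM to 700000 nM.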

Compound 4, half-maximal effective concentration: > 100000 nM
Compound 4: no number, only a limit; the forecaster's own chance of this, stated with the estimate: 80%; the middle value does not contradict the limit.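

In this assay compound 4 gives > 100000 nM, a limit of the assay and not a number. Compound 3 also stands only as a limit, and the step between compound 3 and compound 4 cannot be read in size or direction. The set as a whole sits at one value: the limit of > 100000 nM in this assay, at which 4 of the 4 values shown sit. Left open is which change to the shared core, if any, would give a readable number.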